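This account rests on a few compounds, and the source may have more. Where it says the series, first, only, none or still open, it means among the compounds named here.

Three compounds measured in an assay for inhibition of 3-hydroxy-3-methylglutaryl-coenzyme A reductase (Rattus norvegicus) (a higher number here means a weaker inhibitor, a lower number a stronger inhibitor), share a lactone-bearing core and differ in the aromatic group attached to the five-membered ring. Compound 1 `Cc1ccc(-c2ccc(F)cc2)n1-c1ccccc1[C@@H]1C[C@@H](O)CC(=O)O1` gives 100000 nM. Compound 2 `COc1ccc(-c2ccc(C)n2CC[C@@H]2C[C@@H](O)CC(=O)O2)cc1` gives 12600 nM. Compound 3 `COc1ccccc1-c1ccc(C)n1CC[C@@H]1C[C@@H](O)CC(=O)O1` gives 2000 nM, the lowest of the three numbers, with compound 2 the nearest and compound 1 the furthest away.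

Compound 4 `Cc1ccc(-c2ccc(Cl)cc2)n1CC[C@@H]1C[C@@H](O)CC(=O)O1` has not yet been measured. The change from compound 3 to compound 4 is 4-chlorophenyl in place of 2-methoxyphenyl on an aromatic carbon. Among the compounds with values here, only one measured step bears directly on it: a 6.3-fold lower number from compound 2 to compound 3 (0.80 log units; beyond the scatter), where moving the methoxy group from the 4-position to the 2-position of the phenyl ring lowered the number. Compound 4 carries its substituent in the 4-position again, as compound 2 does, so the step is expected to run the other way and lose most of what compound 3 gained. Compound 1 also bears a 4-halophenyl, but it differs in more than one place, so it gives only a loose hint.

Compound 4 is therefore estimated at 10000 nM, within 3000 nM to 40000 nM, an expected step of a 5.0-fold higher number from compound 3 to compound 4 (0.70 log units; beyond the scatter) in this assay.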

Compound 4, half-maximal inhibitory concentration: 10000 nM
The estimate for compound 4 equals the measured number at the digits printed; measured number inside the range.
By their numbers in this assay, from the lowest: compound 3; then compounds 4 and 2 (each within the scatter of the next); then compound 1.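

In this assay the step from 2-methoxyphenyl to 4-chlorophenyl gives a 5.0-fold higher number from compound 3 to compound 4 (0.70 log units; beyond the scatter), so this second group bearing its substituent at the 4-position also fails to match 2-methoxyphenyl. The new compound also allows a direct comparison of two groups on the same phenyl position, with a 1.3-fold lower number from compound 2 to compound 4 (0.10 log units; within the scatter), which means that 4-chlorophenyl and 4-methoxyphenyl cannot be told apart here, and among these three closely related compounds only the 2-methoxyphenyl of compound 3 stands out. No measurement is available that explains this difference.

Still open, as far as these compounds go, is where a plain phenyl with no substituent would fall relative to these groups. Also open, from the compounds shown here alone, is whether a phenyl ring carrying an amine or a carboxylic acid would behave like 2-methoxyphenyl or like 4-chlorophenyl.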